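Replacing a phenyl by dimethylamino on the hydrazone aryl ring

This account rests on a few compounds, and the source may have more. Where it says the series, first, only, none or still open, it means among the compounds named here.

Compound 1 `CC(=O)Nc1ccc(/C=N/Nc2nc(N)c3ncn([C@@H]4O[C@H](CO)[C@@H](O)[C@H]4O)c3n2)cc1`: in an assay on CHO-K1 cells for displacement of a labelled ligand from adenosine receptor A1 (Homo sapiens), read by scintillation counting, with a stated time of 60 min (a higher number here means a weaker inhibitor, a lower number a stronger inhibitor), compound 1 gives > 10000 nM, which is a limit of the assay and not a number.
Compound 2 `COc1ccc(/C=N/Nc2nc(N)c3ncn([C@@H]4O[C@H](CO)[C@@H](O)[C@H]4O)c3n2)cn1`: compound 2 gives 2.6 nM.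
Compound 3 `Nc1nc(N/N=C/c2ccc(-c3ccccc3)cc2)nc2c1ncn2[C@@H]1O[C@H](CO)[C@@H](O)[C@H]1O`: compound 3 gives 7860 nM.

Of the two actual numbers, compound 3 has the higher one, and compound 2 the lower; the value of compound 1 is a limit only, as recorded in the limit of > 10000 nM in this assay, at which 1 of the 3 values shown sits.

Compound 4 `CN(C)c1ccc(/C=N/Nc2nc(N)c3ncn([C@@H]4O[C@H](CO)[C@@H](O)[C@H]4O)c3n2)cc1` differs from compound 3 by dimethylamino in place of phenyl on an aromatic carbon. Within the data shown here, two measured steps touch this part of the molecule. The step of an at least 1.2-fold lower number from compound 1 to compound 3 (0.10 log units; that floor lies within the scatter) stayed within the scatter, so acetamido and phenyl behave alike here. The step of an at least 3800-fold lower number from compound 1 to compound 2 (3.58 log units; beyond the scatter) was very large, but it changed both the ring and its substituent at once, so it does not isolate the effect of a small group on a plain carbon ring. Neither step replaces phenyl by dimethylamino directly. Given that compound 2 shows a small substituent can go with a very low number, the step of a 20-fold lower number from compound 3 to compound 4 (1.29 log units; beyond the scatter) is expected to run toward a lower number, with wide uncertainty. Compound 4 is therefore estimated at 400 nM, in a range from 20 nM to 8000 nM.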

Compound 4, inhibition constant: > 10000 nM
Compound 4 was reported as a limit; the forecaster's own chance of this, stated with the estimate: 10%; at least 25-fold (1.39 log units) between middle value and limit.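

Putting dimethylamino in place of phenyl gives an at least 1.2-fold higher number from compound 3 to compound 4 (0.10 log units; that floor lies within the scatter) and so brings no drop in the number, which means that swapping in this smaller group on the carbon ring is not enough to reach a low value. The comparison with the most active compound, an at least 3800-fold higher number from compound 2 to compound 4 (3.58 log units; beyond the scatter), shows that a compact substituent alone does not carry the low number of compound 2, which goes with the whole 6-methoxypyridin-3-yl unit among these compounds. In this assay compound 4 gives a limit and not a number, as compound 1 does: the limit of > 10000 nM in this assay, at which 2 of the 4 values shown sit.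

The step between compound 1 and compound 4 cannot be read, since both results are limits. Still open, on these data alone, is whether the low number follows the ring nitrogen or the methoxy group of compound 2, and how a primary amine or a carboxylic acid on the carbon ring would read.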